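The source may hold more compounds than are shown below. What is called first, only, known or untested is meant among the compounds shown, and "the series" means these compounds.

Compound 1 `N#Cc1c(-c2ccccc2)nc(SCC(=O)Nn2c(COc3ccc(Cl)cc3Cl)nc3ccccc3c2=O)n(Cc2ccccc2)c1=O` and compound 2 `N#Cc1c(-c2ccc(Cl)cc2)nc(SCC(=O)Nn2c(COc3ccc(Cl)cc3Cl)nc3ccccc3c2=O)n(Cc2ccccc2)c1=O` share one core, while compound 3 `N#Cc1c(Nc2ccccc2)nc(SCC(=O)Nn2c(COc3ccc(Cl)cc3Cl)nc3ccccc3c2=O)nc1-c1ccccc1` and compound 4 `N#Cc1c(Nc2ccc(Cl)cc2)nc(SCC(=O)Nn2c(COc3ccc(Cl)cc3Cl)nc3ccccc3c2=O)nc1-c1ccccc1` share another; the difference between the two cores is not broken down here. In a functional assay on the whole organism (strain albino) for inhibition, with Rattus norvegicus as the target, read by paw edema, with stated times of 1 h and 2 h, at a dose of 100 mg/kg by the oral route (a lower number here means less inhibition, a higher number more inhibition at the dose given (going by the name of the read-out)), compound 1 gives 79%, and compound 2 gives 77.2%. The change between them is chloro in place of hydrogen on an aromatic carbon, and it made a number 1.8 percentage points lower from compound 1 to compound 2 (within the scatter). In this assay compound 3 gives 78.1%. The change from compound 3 to compound 4 is chloro in place of hydrogen on an aromatic carbon, the same change at the same place, occurring twice among these compounds. From compound 3 to compound 4 a step of a number 1.1 percentage points lower from compound 3 to compound 4 (within the scatter) is expected. This expectation rests on the earlier step of a number 1.8 percentage points lower from compound 1 to compound 2 (within the scatter), which stayed within the scatter. Compound 4 is therefore estimated to give about 77% in this assay, expected to fall between 68% and 86%.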

Compound 4, a percentage reported as inhibition, in the whole organism at one dose (the size of the read-out at that dose, not a potency): 57.9%
Estimate against measurement, compound 4: 19.1 percentage points above; the whole stated range lies above it.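

In this assay, chloro in place of hydrogen on the core of compound 3 made a number 20.2 percentage points lower from compound 3 to compound 4 (beyond the scatter). Within the data shown here, the effect of this change therefore did not carry over from one core to the other, so the earlier step was a poor guide to this one: the same change on two cores in this assay, a number 1.8 percentage points lower (within the scatter) from compound 1 to compound 2 and a number 20.2 percentage points lower (beyond the scatter) from compound 3 to compound 4, 18.4 percentage points apart, beyond the scatter of two such steps With only one such pair on each core, this does not show which difference between the cores is responsible, or how the change would behave on any further core.

The compounds shown leave open whether the drop is specific to chloro. A fluoro or methoxy group at the same place on the core of compound 3 could tell whether other groups there bring a similar drop.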